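Phenoxy in Place of Chlorophenyl: Expected Inhibitory Concentration

This account rests on a few compounds, and the source may have more. Where it says the series, first, only, none or still open, it means among the compounds named here.

Three compounds have been measured in a functional assay for inhibition of sodium/hydrogen exchanger (Oryctolagus cuniculus); a higher number here means a weaker inhibitor, a lower number a stronger inhibitor:

Compound 1 `CCc1cc(Br)c(S(C)(=O)=O)cc1C(=O)N=C(N)N`: 41 nM
Compound 2 `Cc1cc(Br)c(C(=O)N=C(N)N)cc1S(C)(=O)=O`: 70 nM
Compound 3 `Cc1cc(-c2ccc(Cl)cc2)c(S(C)(=O)=O)cc1C(=O)N=C(N)N`: 45 nM

Compound 3 carries the second highest of the three numbers. Its nearest neighbour is compound 1, whose number is slightly lower, and its furthest is compound 2, whose number is higher; both gaps lie within the usual scatter, so the three compounds cannot be ranked against one another.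

Compound 4 `Cc1cc(Oc2ccccc2)c(S(C)(=O)=O)cc1C(=O)N=C(N)N` is not yet measured. It differs from compound 3 in one place: phenoxy in place of 4-chlorophenyl on an aromatic carbon. For the measured compounds named here, no measured pair shows this change, so the expected step from compound 3 to compound 4 is estimated as a 1.3-fold higher number from compound 3 to compound 4 (0.12 log units; within the scatter), a small shift toward a somewhat higher number that does not clearly exceed the scatter. Compound 4 is therefore expected to give 60 nM, with a range from 25 nM to 150 nM.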

Compound 4, half-maximal inhibitory concentration: 10 nM
For compound 4 the middle estimate is 6.0-fold (0.78 log units) above the measured one; measured number below the stated range.
By their numbers in this assay, from the lowest: compound 4; then compounds 1, 3 and 2 (each within the scatter of the next).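

In this assay, for the compounds shown here, the aromatic carbon ortho to a methylsulfonyl group proves sensitive to what it carries: phenoxy in place of 4-chlorophenyl gives a 4.5-fold lower number from compound 3 to compound 4 (0.65 log units; beyond the scatter), the only step between compounds differing in one place. No available measurement bears on why the number falls.

The change removes the chlorine and introduces the oxygen together, so the compounds shown do not separate the two. As far as these compounds go, whether 4-chlorophenoxy or plain phenyl here would track compound 3 or compound 4 stays open, as does the outcome with benzyloxy.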